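A few compounds are considered here, and "the series" means these few. Any claim that something is new, unique, unknown or untested is made for them only; others in the source may bear on it.

Values in an ADME assay on cells (Hepatocyte, Rattus norvegicus) for pharmacokinetics, read by LC-MS, with a stated time of 90 min, tested at 1 uM (a lower number here means slower removal, a higher number faster removal of the compound), for the measured compounds:
compound 1 `COC(=O)N(Cc1ccc(F)cc1)c1c(N)nc(-c2nn(Cc3ccccc3F)c3ncccc23)nc1N` gives 40 mL/min/kg
compound 2 `CC(C)OC(=O)Nc1c(N)nc(-c2nn(Cc3ccccc3F)c3ncccc23)nc1N` gives 15 mL/min/kg

Compound 2 holds the lower of the two numbers, with a gap to compound 1 that lies beyond the scatter. Compound 3 `Nc1nc(-c2nn(Cc3ccccc3F)c3ncccc23)nc(N)c1NC(=O)OCC1CC1` is not yet measured and carries the change cyclopropylmethyl in place of isopropyl on an oxygen next to a carbonyl group relative to compound 2, with cyclopropylmethyl in place of isopropyl on an oxygen next to a carbonyl group. For the measured compounds named here, no measured pair covers this change, so only a slight rise in this assay is expected, none beyond the scatter. The expected step of a 1.3-fold higher number from compound 2 to compound 3 (0.12 log units; within the scatter) rests on the structural change alone. Expected for compound 3 is 20 mL/min/kg within an estimated range of 10 mL/min/kg to 40 mL/min/kg for now.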

Compound 3, clearance: 23.3 mL/min/kg
The estimate for compound 3 lay 1.2-fold (0.07 log units) below the measured number; the range from low to high includes it.
By their numbers in this assay, from the lowest: compounds 2, 3 and 1 (each within the scatter of the next, the first and the last beyond it).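

For the compounds shown here, on an oxygen next to a carbonyl group, cyclopropylmethyl in place of isopropyl gives the first single-place comparison of the series in this assay, with a 1.6-fold higher number from compound 2 to compound 3 (0.19 log units; within the scatter) as its step. Compound 2 and compound 3 cannot be told apart here, so this position accepts a three-membered ring without a difference beyond the scatter. Nothing available explains the step.

As far as these compounds go, it remains open whether a longer chain or a terminal amine on this oxygen would separate from compound 2 beyond the scatter. Also open, from the compounds shown here alone, is whether this swap reads the same on a nitrogen substituted as in compound 1.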